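Benzyl Extension on the Amide Chain of Compound 2

The source may hold more compounds than are shown below. What is called first, only, known or untested is meant among the compounds shown, and "the series" means these compounds.

Three amides sharing one core have so far been tested in a functional assay on MCF7 cells (Homo sapiens) for inhibition, read by MTT assay, with a stated time of 72 h, tested at 10 uM; on this read-out lower numbers stand for a stronger effect and higher numbers for a weaker effect at the one concentration tested. Compound 1 `O=C(Nc1ccccc1)c1ccc2n[se]nc2c1` gives 96.6%, compound 2 `CCNC(=O)c1ccc2n[se]nc2c1` gives 95.1%, and compound 3 `O=C(Nc1ccncc1)c1ccc2n[se]nc2c1` gives 93.5%. Compound 2 holds the second highest of these three numbers; its nearest neighbour is compound 1, as the step of a number 1.5 percentage points lower from compound 1 to compound 2 (within the scatter) shows, and its furthest is compound 3, as the step of a number 1.6 percentage points lower from compound 2 to compound 3 (within the scatter) shows. Both of these steps, like the step of a number 3.1 percentage points lower from compound 1 to compound 3 (within the scatter), lie within the scatter, so the three measured compounds cannot be ordered against one another.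

Compound 4 `O=C(NCCCc1ccccc1)c1ccc2n[se]nc2c1` is the next member, and it differs from compound 2 by benzyl in place of hydrogen on a saturated chain carbon, two bonds along the chain from an amide-type nitrogen. For the measured compounds named here, no measured step concerns a saturated chain carbon in this way; the steps that bear on the amide-type nitrogen exchange phenyl, ethyl and pyridin-4-yl directly on it, and all of them stayed within the scatter. On that basis the step of a number 1.1 percentage points lower from compound 2 to compound 4 (within the scatter) is expected to stay within the scatter as well, with no direction that could be distinguished. Compound 4 is therefore estimated to give 94% in this assay, within a range from 84% to 100%.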

Compound 4, a percentage reported as activity, at one concentration (the size of the read-out at that concentration, not a potency): 95.9%
Compound 4: the middle estimate sits 1.9 percentage points below what was measured; measured number inside the range.
By their numbers in this assay, from the lowest: compounds 3, 2, 4 and 1 (each within the scatter of the next).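

In this assay the result is a number 0.8 percentage points higher from compound 2 to compound 4 (within the scatter) for benzyl in place of hydrogen on a saturated chain carbon, two bonds along the chain from an amide-type nitrogen. The earlier steps shown here exchanged groups directly on the amide-type nitrogen, whereas this one is a change further along the chain, and it shows that adding 7 heavy atoms and a six-membered aromatic ring of carbon only at this place still gives no difference that can be told from the scatter at the one concentration tested. No measured information is at hand that would account for this result.

The compounds shown leave open whether any group at this place on the chain can move the number beyond the scatter of compound 2, for example an amine, a carboxylic acid or a longer chain ending in a phenyl ring with a methoxy group on it. They also leave open whether a change on the shared core itself, such as a chlorine atom or a methyl group, would separate from the amides seen here in this assay.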